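Larger Group on the Side Chain of Compound 2

This account rests on a few compounds, and the source may have more. Where it says the series, first, only, none or still open, it means among the compounds named here.

The two measured compounds share one core and differ only in the group on the chain that hangs from the ring attached to that core. Compound 1 `COCCOC1CCN(c2nc(N)c3cc(OC)c(OC)cc3n2)CC1` gives 2.12 nM in an assay on brain for displacement of a labelled ligand from Adrenergic receptor alpha-1 (Rattus norvegicus); on this read-out higher numbers stand for weaker inhibition and lower numbers for stronger inhibition. Compound 2 `COc1cc2nc(N3CCC(OCC(C)(C)OC)CC3)nc(N)c2cc1OC` gives 1.14 nM in this assay. Among the measured compounds shown here, compound 2 stands at the lowest of the two numbers, but its only neighbour is compound 1, and the step of a 1.9-fold lower number from compound 1 to compound 2 (0.27 log units; within the scatter) is within the scatter, so the two cannot be told apart.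

Compound 3 `COc1cc2nc(N3CCC(OCC(C)(O)c4ccccc4)CC3)nc(N)c2cc1OC` is not yet measured. It differs from compound 2 by 1-hydroxy-1-phenylethyl in place of 1-methoxy-1-methylethyl on a saturated chain carbon bound to an oxygen on a saturated carbon. For the measured compounds named here, the one measured step, from compound 1 to compound 2, changed the same chain carbon and produced no movement beyond the scatter, which hints that this position tolerates some variation; no measured step adds a ring or a hydroxyl there. The expectation is therefore a step of about a 1.3-fold higher number from compound 2 to compound 3 (0.12 log units; within the scatter) from compound 2 to compound 3, none beyond the scatter. Compound 3 is expected to give about 1.5 nM, in a range from 0.4 nM to 6 nM.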

Compound 3, inhibition constant: 0.62 nM
Beside the measured number, compound 3's estimate is 2.4-fold (0.38 log units) above it; low and high end bracket the measured number.
By their numbers in this assay, from the lowest: compounds 3, 2 and 1 (each within the scatter of the next, the first and the last beyond it).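

In this assay, among the compounds shown here, this chain position accepts a far larger group than the earlier compounds carried: 1-hydroxy-1-phenylethyl brings a six-membered aromatic ring and a hydrogen-bond donor, both absent from 1-methoxy-1-methylethyl, yet the result is a 1.8-fold lower number from compound 2 to compound 3 (0.26 log units; within the scatter) and the two compounds cannot be told apart. Set against the smaller methoxymethyl, the same group gives a 3.4-fold lower number from compound 1 to compound 3 (0.53 log units; beyond the scatter), a modest step and the first here to clear the scatter, so a difference at this position now shows up in the numbers. No measurement here explains why these groups give these numbers.

The aromatic ring and the hydroxyl entered together, so the compounds shown cannot separate their contributions; 1-hydroxy-1-methylethyl, which keeps the hydroxyl without the ring, and 1-methoxy-1-phenylethyl, which keeps the ring without the hydroxyl, would pull the two apart. Also open, as far as these compounds go, is how this position responds to a group of another kind, such as an amine or a carboxylic acid, or to a longer chain carrying the phenyl ring further out.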